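Replacing the large arm of compound 2

The compounds below may be only part of what the source reports. "The series", "measured", "known", "first", "only" and "open" are said of these compounds alone.

Values in a functional assay on SGC-7901 cells (Homo sapiens) for inhibition, read by MTT assay, with a stated time of 72 h; a lower number here means a stronger inhibitor of growth, a higher number a weaker inhibitor of growth:
- Compound 1 `CC1=C(C)C(=O)C(CCCCCCCCCCn2cc(C[C@H](O)COCCOC[C@@H](O)Cc3ccc(-c4ccccc4)cc3)nn2)=C(C)C1=O`: 350 nM
- Compound 2 `O[C@H](COCCOC[C@@H](O)Cc1cn(Cc2ccc3ccccc3c2)nn1)Cc1ccc(-c2ccccc2)cc1`: 12100 nM
- Compound 3 `O[C@H](COCCOC[C@@H](O)Cc1cn(Cc2cccc(-c3ccccc3)c2)nn1)Cc1ccc(-c2ccccc2)cc1`: 10600 nM

Compound 2 sits well above compound 1 on these numbers, so it is a much weaker growth inhibitor than compound 1. Compound 4 `O[C@H](COCCOC[C@@H](O)Cc1cn(-c2cccnc2)nn1)Cc1ccc(-c2ccccc2)cc1` carries pyridin-3-yl in place of (naphthalen-2-yl)methyl on an aromatic nitrogen. Going by the values given here, only one measured step changes this arm: a 1.1-fold lower number from compound 2 to compound 3 (0.06 log units; within the scatter). That step swapped one large group for another, so it offers only a weak guide to this swap. No step beyond the scatter is therefore expected in this assay, though the uncertainty is wide. The estimated step is a 1.1-fold higher number from compound 2 to compound 4 (0.03 log units; within the scatter). For compound 4 the expected value is 13000 nM, with an estimated range of 5000 nM to 35000 nM.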

Compound 4, concentration for 50% growth inhibition: 29800 nM
Beside the measured number, compound 4's estimate is 2.3-fold (0.36 log units) below it, within the range that was stated.
By their numbers in this assay, from the lowest: compound 1; then compounds 3 and 2 (each within the scatter of the next); then compound 4.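

On this aromatic nitrogen of the five-membered ring, the arm can change the result in this assay: pyridin-3-yl in place of (naphthalen-2-yl)methyl gives a 2.5-fold higher number from compound 2 to compound 4 (0.39 log units; beyond the scatter). Going by these compounds alone, this is a modest loss of growth inhibition, and the first step at this position to lie beyond the scatter. No measurement shown accounts for this shift. On these data alone, the swap changes the ring system and removes the carbon link together, so their separate contributions remain unknown. As far as these compounds go, whether an arm ending in an amine or a carboxylic acid could approach compound 1 at 350 nM also remains open.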